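Oxygen in the acid chain of a thromboxane receptor ligand

This account rests on a few compounds, and the source may have more. Where it says the series, first, only, none or still open, it means among the compounds named here.

Three compounds have been measured in a functional assay on a cell-free system (plasma) for agonist activity at thromboxane A2 receptor (Homo sapiens); a lower number here means a stronger inhibitor, a higher number a weaker inhibitor:
compound 1 `O=C(O)CCC/C=C1/C[C@H]2C[C@@H](O)[C@H](/C=N/NC(=O)Nc3ccc([N+](=O)[O-])cc3)[C@H]2C1` gives 50 nM;
compound 2 `O=C(O)CCC/C=C1\C[C@H]2C[C@@H](O)[C@H](/C=N/NC(=O)Nc3ccc([N+](=O)[O-])cc3)[C@H]2C1` gives 60 nM;
compound 3 `O=C(O)CCC/C=C1\C[C@H]2CC[C@H](/C=N/NC(=O)Nc3ccc([N+](=O)[O-])cc3)[C@H]2C1` gives 1700 nM.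

Compound 2 stands second highest of these three numbers. Its nearest neighbour is compound 1: a 1.2-fold higher number from compound 1 to compound 2 (0.08 log units; within the scatter), a step that stays within the scatter. The two share all atoms and bonds and differ only in how one double bond is drawn, which is the whole of the fact that compounds 1 and 2 differ only in the configuration as drawn. Compound 3 lies furthest away: a 28-fold higher number from compound 2 to compound 3 (1.45 log units; beyond the scatter), when hydrogen replaces hydroxy on a saturated ring carbon.

Compound 4 `O=C(O)COC/C=C1\C[C@H]2C[C@@H](O)[C@H](/C=N/NC(=O)Nc3ccc([N+](=O)[O-])cc3)[C@H]2C1` has not been measured. It keeps the hydroxy and the same drawing of the double bond as compound 2 and alters only the acid chain: carboxymethoxy in place of 2-carboxyethyl on a saturated chain carbon bound to a double-bonded chain carbon. Neither measured step touches that chain. The stereochemical step was small and the hydroxy step was large, but the hydroxy is untouched here and the acid group remains, so only a modest step is expected, a 1.5-fold higher number from compound 2 to compound 4 (0.18 log units; within the scatter), without a firm direction beyond the scatter. Compound 4 is therefore estimated at 90 nM in this assay, with a range of 30 nM to 300 nM.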

Compound 4, half-maximal inhibitory concentration: 190 nM
The estimate for compound 4 lay 2.1-fold (0.32 log units) below the measured number, and the stated range covers the measured number.
By their numbers in this assay, from the lowest: compounds 1 and 2 (each within the scatter of the next); then compound 4; then compound 3.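

In this assay, the acid chain proves to be more than a passive link to the acid group: carboxymethoxy in place of 2-carboxyethyl, on a saturated chain carbon bound to a double-bonded chain carbon, gives a 3.2-fold higher number from compound 2 to compound 4 (0.50 log units; beyond the scatter). The chain keeps its number of heavy atoms and its carboxylic acid, and the counted differences are one carbon traded for an oxygen and one more hydrogen-bond acceptor, so even this small edit moves the number beyond the scatter. The step is still modest beside the loss of the ring hydroxy, which gives a 28-fold higher number from compound 2 to compound 3 (1.45 log units; beyond the scatter), and nothing at hand explains why the chain edit has the effect it does.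

The compounds shown cannot tell whether this result is specific to oxygen, since a sulfur atom at the same place in the chain, or a longer chain carrying the acid, would be needed to test that. They also leave open whether the same edit would give a similar step in compound 1, whose double bond is drawn the other way.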